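A Chloro Added to the Anilino Ring of Compound 2

The source may report more compounds than this note shows. Statements on the series, on what has been measured and on what is new or still open speak of the compounds shown alone.

Measured compounds:
compound 1, `O=C1COCCN1c1ccc(Nc2nc(Cl)nc(N3CCCC3)n2)cc1`: 93%
compound 2, `O=C1COCCN1c1ccc(Nc2nc(Cl)nc(Nc3ccccc3)n2)cc1`: 83%

Two compounds sharing one core have so far been examined in a functional assay on the whole organism (strain Swiss) for inhibition, with Mus musculus as the target, with a stated time of 30 min, at a dose of 10 mg/kg by the intraperitoneal route; a higher number here means a stronger effect of the compound at the dose given, a lower number a weaker effect. In this assay compound 1 gives 93%. Compound 2 carries anilino in place of pyrrolidin-1-yl on an aromatic carbon, and in this assay compound 2 gives 83%. For the measured compounds named here, the single step between them, a number 10 percentage points lower from compound 1 to compound 2 (within the scatter), is within the scatter. Compound 2 thus stands lowest of the two numbers, with compound 1 as its nearest neighbour, and the two cannot be set in order.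

Compound 3, `O=C1COCCN1c1ccc(Nc2nc(Cl)nc(Nc3ccc(Cl)cc3)n2)cc1`, differs from compound 2 in one place: chloro in place of hydrogen on an aromatic carbon. Going by the values given here, no measured step involves this kind of change, so the only step available, which concerned a different group, bears on it weakly at best. It shows that a larger exchange on the same core moved the number within the scatter.

On that basis compound 3 is expected to give about 80% in this assay, between 60% and 96%, an estimated step of a number 3 percentage points lower from compound 2 to compound 3 (within the scatter) that stays within the scatter.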

Compound 3, a percentage reported as inhibition, in the whole organism at one dose (the size of the read-out at that dose, not a potency): 90.2%
The estimate for compound 3 lay 10.2 percentage points below the measured number, within the range that was stated.
By their numbers in this assay, from the lowest: compounds 2, 3 and 1 (each within the scatter of the next).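

For the compounds shown here, the change from phenyl to 4-chlorophenyl, with chloro entering on an aromatic carbon para to a large group, comes with a number 7.2 percentage points higher from compound 2 to compound 3 (within the scatter) in this assay and is the first look at a substituent on the anilino ring: this place takes the chloro without a step beyond the scatter. The exchange of (4-chlorophenyl)amino for pyrrolidin-1-yl comes with a number 2.8 percentage points lower from compound 1 to compound 3 (within the scatter) and so also stays within the scatter, which leaves compounds 1, 2 and 3 impossible to set in order at this dose. No measurement is available that would explain these numbers or say what the added chloro does here.

The compounds shown leave open whether other groups at this same place on the anilino ring, such as fluoro, methoxy or a carboxylic acid, would also stay within the scatter. They also leave open whether the chloro on the shared core could give way to an amine or a methoxy group with the number held, and readings at a single dose cannot show whether potency differs among the three compounds.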